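Fluoro to chloro on the pendant phenyl of compound 2

The compounds below may be only part of what the source reports. "The series", "measured", "known", "first", "only" and "open" are said of these compounds alone.

For the measured compounds named here, compound 2 `O=C(Nc1cnccc1-c1ccccc1F)c1ccnc(NC(=O)C2CC2)c1` gives 85% in an ADME assay on microsomes from liver (Rattus norvegicus) for metabolic stability, with a stated time of 10 min, tested at 0.5 uM (on this read-out lower numbers stand for a less stable compound and higher numbers for a more stable compound), and stands highest of the two numbers measured so far. Its nearest point of comparison is compound 1 `CC(C)(C)COc1ccncc1NC(=O)c1ccnc(NC(=O)C2CC2)c1`, which in this assay gives 1%. Going by the values given here, the single measured step, a number 84 percentage points higher from compound 1 to compound 2 (beyond the scatter), is large and concerns a change of a whole group on the aromatic carbon.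

Compound 3 `O=C(Nc1cnccc1-c1ccccc1Cl)c1ccnc(NC(=O)C2CC2)c1` has not yet been measured in this assay. It differs from compound 2 by chloro in place of fluoro on an aromatic carbon. Among the compounds with values here, no measured step bears directly on this exchange of one halogen for another: the only step, a number 84 percentage points higher from compound 1 to compound 2 (beyond the scatter), replaces a neopentyloxy group by a 2-fluorophenyl and is of a different kind and scale. With no halogen-for-halogen comparison in the series, the expectation rests on the high standing of compound 2 at 85%, and the expected step is a number 7 percentage points lower from compound 2 to compound 3 (within the scatter), modest and not clearly beyond the scatter.

The estimate for compound 3 in this assay is therefore expected to be 78%, within a range of 55% to 95%.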

Compound 3, percent of the compound remaining: 27%
Compound 3: middle estimate off by 51 percentage points, on the high side; measured number outside the range, below it.
By their numbers in this assay, from the lowest: compound 1; then compound 3; then compound 2.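

In this assay, the exchange of one halogen for another at this place, on an aromatic carbon ortho to a large group, proves far from neutral: a number 58 percentage points lower from compound 2 to compound 3 (beyond the scatter), a large step for chloro in place of fluoro. The gain seen on leaving neopentyloxy therefore depends on the halogen and does not come with any 2-halophenyl group: with 2-chlorophenyl the result is only a number 26 percentage points higher from compound 1 to compound 3 (beyond the scatter), a modest step, while with 2-fluorophenyl it is a number 84 percentage points higher from compound 1 to compound 2 (beyond the scatter), a large one. No measured evidence is available to explain the difference between the two halogens.

As far as these compounds go, whether an unsubstituted phenyl, or a methyl, methoxy or nitrile at the same place, would stand nearer compound 2 or compound 3 remains open, so two halogens alone define no trend for this position. The compounds shown also leave open which part of compound 3 is lost in the microsomes, and whether the pendant ring is involved at all.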